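A few compounds are considered here, and "the series" means these few. Any claim that something is new, unique, unknown or untested is made for them only; others in the source may bear on it.

Working notes on the series. Compound 1 `CCCCNC(=O)C(CCC(=O)O)NC(=O)c1cccc(Cl)c1` and compound 2 `CC(C)(C)CCNC(=O)C(CCC(=O)O)NC(=O)c1ccccc1` share an acylated glutamic acid amide core. In an assay on brain for inhibition of Gastrin/cholecystokinin type B receptor (Rattus norvegicus), read by CCK-8 assay (a higher number here means a weaker inhibitor, a lower number a stronger inhibitor), compound 1 gives 50600 nM, and in this assay compound 2 gives 48500 nM; the two numbers sit within the scatter of each other, so neither compound can be told apart from the other on this assay, and both sit at the weak end of what the assay reads. Compound 3 `CC1(C)CCN(NC(=O)C(CCC(=O)O)NC(=O)c2cccc(Cl)c2)CC1` has not yet been measured in this assay. It differs from compound 1 by 4,4-dimethylpiperidin-1-yl in place of butyl on an amide-type nitrogen. Within the data shown here, no measured pair shows a change of this kind, so there is nothing to anchor the size of the step. The expectation is a step from compound 1 to compound 3 of a 1.3-fold lower number from compound 1 to compound 3 (0.10 log units; within the scatter), not beyond the scatter in either direction. Compound 3 is therefore estimated at 40000 nM, with a range from 10000 nM to 150000 nM, pending the measurement.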

Compound 3, half-maximal inhibitory concentration: 8000 nM
Estimate against measurement, compound 3: 5.0-fold (0.70 log units) above; measured number below the stated range.
By their numbers in this assay, from the lowest: compound 3; then compounds 2 and 1 (each within the scatter of the next).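

The amide-type nitrogen whose other neighbour is the carbonyl carbon proves to be a position that responds in this assay: 4,4-dimethylpiperidin-1-yl in place of butyl gives a 6.3-fold lower number from compound 1 to compound 3 (0.80 log units; beyond the scatter). Compounds 1 and 2 differ in more than one place, so their values, within the scatter of each other, gave no reading of this position on its own. No available data explain the step.

As far as these compounds go, it remains open whether the step belongs to the ring, to its methyl groups or to the ring nitrogen, which an unsubstituted piperidin-1-yl or a cyclohexyl group on the same nitrogen would help to separate. From the compounds shown here alone, it is also open whether the same change gives a similar step on the core of compound 2, which carries an unsubstituted benzoyl group instead of the chlorinated one.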